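A Hydroxycyclohexyl Replaces the Hydroxycycloheptyl Group

The source may report more compounds than this note shows. Statements on the series, on what has been measured and on what is new or still open speak of the compounds shown alone.

Compound 1 `O=C(NCCCOc1ccc2nc(O)ccc2c1)N(C1CCCCC1)C1CC1`: 15%
Compound 2 `O=C(NCCCOc1ccc2nc(O)ccc2c1)N(C1CC1)[C@@H]1CCCCC[C@H]1O`: 0%

In a functional assay on the whole organism for inhibition, with Rattus norvegicus as the target, at a dose of 30 mg/kg by the oral route (a higher number here means more inhibition at the dose given (going by the name of the read-out), a lower number less inhibition), compound 1 gives 15%, while compound 2 gives 0%, the lowest of the two numbers measured. Going by the values given here, the only measured step, a number 15 percentage points lower from compound 1 to compound 2 (beyond the scatter), lowered the read-out. Compound 3 `O=C(NCCCOc1ccc2nc(O)ccc2c1)N(C1CC1)[C@@H]1CCC[C@@H](O)C1` differs from compound 2 by 3-hydroxycyclohexyl in place of 2-hydroxycycloheptyl on an amide-type nitrogen. Among the compounds with values here, no measured step covers this exact change. Compound 2 already gives 0%, so the read-out cannot fall further, and a small rise or no change beyond the scatter is expected, a number 5 percentage points higher from compound 2 to compound 3 (within the scatter). Compound 3 is estimated at 5%, between 0% and 20%.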

Compound 3, a percentage reported as inhibition, in the whole organism at one dose (the size of the read-out at that dose, not a potency): 0%
Compound 3: the middle estimate sits 5 percentage points above what was measured; the measured number falls inside the stated range.
By their numbers in this assay, from the lowest: compounds 2 and 3 (each within the scatter of the next); then compound 1.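

In this assay, 3-hydroxycyclohexyl in place of 2-hydroxycycloheptyl on the amide-type nitrogen gives no change at the digits printed from compound 2 to compound 3 (within the scatter), so these two hydroxylated rings cannot be told apart here. Compound 1 and compound 3 both carry a six-membered ring at this position, and hydroxy in place of hydrogen on a saturated ring carbon gives a number 15 percentage points lower from compound 1 to compound 3 (beyond the scatter), a drop seen without any change in ring size. Nothing available explains this drop. As far as these compounds go, it remains open whether a methoxy group or an amine at that ring carbon would keep the read-out of compound 1.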